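This account rests on a few compounds, and the source may have more. Where it says the series, first, only, none or still open, it means among the compounds named here.

Measured so far in an assay on HEK293 cells for inhibition of Steryl-sulfatase (Homo sapiens), tested at 0.1 uM; on this read-out higher numbers stand for a stronger effect at the one concentration tested and lower numbers for a weaker effect:

compound 1 `CC(C)CCN(CCC(C)C)c1ccc(C(=O)N2CCc3ccc(OS(N)(=O)=O)cc3C2)cc1` – 47%
compound 2 `CCN(Cc1ccccn1)c1ccc(C(=O)N2CCc3ccc(OS(N)(=O)=O)cc3C2)cc1` – 42.5%
compound 3 `CCN(Cc1ccccc1)c1ccc(C(=O)N2CCc3ccc(OS(N)(=O)=O)cc3C2)cc1` – 66.9%

Compound 3 gives the highest of the three numbers in this assay. Its nearest neighbour is compound 1, with a number 19.9 percentage points higher from compound 1 to compound 3 (beyond the scatter), and the furthest is compound 2, with a number 24.4 percentage points higher from compound 2 to compound 3 (beyond the scatter). The remaining pair, compound 1 and compound 2, shows a number 4.5 percentage points lower from compound 1 to compound 2 (within the scatter).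

Compound 4 `CCCN(Cc1ccccc1)c1ccc(C(=O)N2CCc3ccc(OS(N)(=O)=O)cc3C2)cc1` is not yet measured. It differs from compound 3 by methyl in place of hydrogen on a saturated chain carbon, two bonds along the chain from a nitrogen on an aromatic ring. None of the three measured steps changes this part of the molecule: two of them swap the whole diisopentylamino group for a different amino group, and the third replaces pyridin-2-yl with phenyl. Only compound 1, carrying the much larger diisopentylamino group, hints that longer chains on that nitrogen are not rewarded, and that step was only modest. For a single added carbon no step beyond the scatter is therefore expected in this assay, in either direction.

Compound 4 is thus expected to give about 64%, with a range from 50% to 78%, which means an expected step of a number 2.9 percentage points lower from compound 3 to compound 4 (within the scatter) from compound 3.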

Compound 4, a percentage reported as inhibition, at one concentration (the size of the read-out at that concentration, not a potency): 64.8%
Beside the measured number, compound 4's estimate is 0.8 percentage points below it, and the stated range covers the measured number.
By their numbers in this assay, from the lowest: compounds 2 and 1 (each within the scatter of the next); then compounds 4 and 3 (each within the scatter of the next).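

In this assay, among these compounds, the step from ethyl to propyl on the nitrogen of the benzylamino group gives the first reading at this position: methyl in place of hydrogen on a saturated chain carbon, two bonds along the chain from a nitrogen on an aromatic ring, gives a number 2.1 percentage points lower from compound 3 to compound 4 (within the scatter) and so leaves the read-out unchanged within the scatter. The advantage seen for benzyl(ethyl)amino therefore survives the longer chain, with benzyl(propyl)amino in place of diisopentylamino giving a number 17.8 percentage points higher from compound 1 to compound 4 (beyond the scatter) and benzyl(propyl)amino in place of ethyl((pyridin-2-yl)methyl)amino giving a number 22.3 percentage points higher from compound 2 to compound 4 (beyond the scatter) as steps beyond the scatter. No measurement offered here accounts for why this position accepts the extra carbon without a change in the read-out.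

The compounds shown leave open how far this tolerance extends, for example to a butyl chain or a branched isopropyl group on the same nitrogen. They also leave open whether a hydroxyl group at the end of the propyl chain, or a fluorine atom on the phenyl ring of the benzyl group, would move the number beyond the scatter.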